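The compounds below may be only part of what the source reports. "The series", "measured", "known", "first", "only" and "open" are said of these compounds alone.

Among the measured compounds shown here, compound 3 `Cc1cncc(-c2cc(F)cc(-n3nnc(-c4ccccn4)n3)c2)c1` gives 272 nM in an assay for binding affinity to metabotropic glutamate receptor 5 (Rattus norvegicus) (a higher number here means a weaker inhibitor, a lower number a stronger inhibitor), the highest of the three numbers measured so far. Compound 1 `Fc1cc(-c2ccccn2)cc(-n2nnc(-c3ccccn3)n2)c1` gives 95 nM and compound 2 `Cc1ccncc1-c1cc(F)cc(-n2nnc(-c3ccccn3)n2)c1` gives 2 nM. Both steps that separate compound 3 from the others lie beyond the scatter: a 2.9-fold higher number from compound 1 to compound 3 (0.46 log units; beyond the scatter) and a 140-fold higher number from compound 2 to compound 3 (2.13 log units; beyond the scatter). Compound 4 `Nc1ccncc1-c1cc(F)cc(-n2nnc(-c3ccccn3)n2)c1` carries 4-aminopyridin-3-yl in place of 5-methylpyridin-3-yl on an aromatic carbon. For the measured compounds named here, the one measured step that bears directly on this change is a 140-fold higher number from compound 2 to compound 3 (2.13 log units; beyond the scatter), since compound 4 again presents its substituent as a 4-substituted pyridin-3-yl, as compound 2 does, rather than as the 5-methylpyridin-3-yl of compound 3. Going by the values given here, no measured pair compares an amino group with a methyl group on that ring, so the size of the return is uncertain. A large drop in this assay is nevertheless expected for compound 4, an 18-fold lower number from compound 3 to compound 4 (1.26 log units; beyond the scatter), probably not reaching the full extent seen with compound 2. Compound 4 is therefore estimated at 15 nM, with a range from 3 nM to 80 nM.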

Compound 4, inhibition constant: 20 nM
Beside the measured number, compound 4's estimate is 1.3-fold (0.12 log units) below it; low and high end bracket the measured number.
By their numbers in this assay, from the lowest: compound 2; then compound 4; then compound 1; then compound 3.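

In this assay, 4-aminopyridin-3-yl in place of 5-methylpyridin-3-yl gives a 14-fold lower number from compound 3 to compound 4 (1.13 log units; beyond the scatter) and shows that a large change from compound 3 is not confined to the 4-methylpyridin-3-yl group of compound 2. Among the compounds shown here, the group itself still counts, since amino in place of methyl gives a 10-fold higher number from compound 2 to compound 4 (1.00 log units; beyond the scatter) as the first direct comparison of these two groups. Replacing pyridin-2-yl with 4-aminopyridin-3-yl gives a 4.8-fold lower number from compound 1 to compound 4 (0.68 log units; beyond the scatter) and places a second group below compound 1, whereas the 5-methylpyridin-3-yl group of compound 3 stands above it.

Open, going by these compounds, is where a methoxy, hydroxyl or dimethylamino group would fall relative to methyl and amino on this pyridin-3-yl group. Nothing available explains the differences among these groups.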